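Urea to anilino swap on the shared core

The source may report more compounds than this note shows. Statements on the series, on what has been measured and on what is new or still open speak of the compounds shown alone.

Working notes on the series. Compound 1 `C=CCNC(=O)Nc1cncc2nc(-c3ccccc3)cnc12` and compound 2 `CCNC(=O)Nc1nccc2nc(-c3ccccc3)cnc12` carry the same phenyl-bearing core and differ in the ring nitrogens and in the group on the ring nitrogen. In an assay on Sf21 cells for inhibition of high affinity nerve growth factor receptor (Homo sapiens), read by AlphaScreen, with a stated time of 1 h (a higher number here means a weaker inhibitor, a lower number a stronger inhibitor), compound 1 gives > 100000 nM, which is a limit of the assay and not a number. In this assay compound 2 gives > 100000 nM, again a limit rather than a number. Within the data shown here, compound 2 thus stands where every value so far sits, at the limit of > 100000 nM in this assay, at which 2 of the 2 values shown sit, and no step between the two measured compounds can be sized.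

Compound 3 `COc1ccc(Nc2nccc3nc(-c4ccccc4)cnc23)cc1` is not yet measured. It differs from compound 2 by 4-methoxyphenyl in place of ethylcarbamoyl on a nitrogen on an aromatic ring. Nothing measured points to a direction for this change, so the expected step is an at least 3.3-fold lower number from compound 2 to compound 3 (0.52 log units; beyond the scatter), toward a stronger inhibitor but with wide uncertainty. For compound 3 in this assay the estimate is 30000 nM, between 3000 nM and 100000 nM, with a real chance that only a limit is returned again.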

Compound 3, half-maximal inhibitory concentration: > 100000 nM
Compound 3: only a limit was reported; the forecaster's own chance of this, stated with the estimate: 45%; middle value at least 3.3-fold (0.52 log units) away from the limit.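

In this assay compound 3 gives > 100000 nM, a limit of the assay and not a number. Compound 2 also stands at a limit, so no step between compound 2 and compound 3 can be read: the limit of > 100000 nM in this assay, at which 3 of the 3 values shown sit.

The compounds shown leave open whether any change on the shared core gives a measurable value in this assay.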